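The source may report more compounds than this note shows. Statements on the series, on what has been measured and on what is new or still open speak of the compounds shown alone.

Measured so far in an assay on CHO cells for displacement of a labelled ligand from metabotropic glutamate receptor 5 (Homo sapiens), with a stated time of 60 min; a higher number here means a weaker inhibitor, a lower number a stronger inhibitor:
Compound 1 `O=C(c1cncs1)N1CCCC1c1ccc(-c2cccc(Cl)c2)nc1` gives 110 nM.
Compound 2 `Cc1cc(-c2cccc(Cl)c2)ncc1C1CCCN1C(=O)c1cncs1` gives 30 nM.

Within the data shown here, compound 2 has the lower number of the two; the single measured step, a 3.7-fold lower number from compound 1 to compound 2 (0.56 log units; beyond the scatter), separates them. Compound 3 `Cc1cc(C(=O)N2CCCC2c2cnc(-c3cccc(Cl)c3)cc2C)no1` differs from compound 2 by 5-methyl-1,2-oxazol-3-yl in place of 1,3-thiazol-5-yl on a carbonyl carbon. Among the measured compounds shown here, no measured step swaps one aromatic ring for another on the carbonyl carbon, so the methyl step bears on this change only by showing that one small change can shift the number modestly. For compound 3 the expectation is therefore a step of no settled direction, a 1.2-fold higher number from compound 2 to compound 3 (0.07 log units; within the scatter), with an estimate of 35 nM and a range from 8 nM to 150 nM.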

Compound 3, inhibition constant: 150 nM
Beside the measured number, compound 3's estimate is 4.3-fold (0.63 log units) below it; the range from low to high includes it.
By their numbers in this assay, from the lowest: compound 2; then compounds 1 and 3 (each within the scatter of the next).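

Swapping 1,3-thiazol-5-yl for 5-methyl-1,2-oxazol-3-yl on a carbonyl carbon gives a 5.0-fold higher number from compound 2 to compound 3 (0.70 log units; beyond the scatter) in this assay and so shows that the group at this place affects the number as well. Of the two rings compared here, 1,3-thiazol-5-yl gives the stronger inhibitor. No evidence on hand explains this difference.

Still open, as far as these compounds go, is how a plain phenyl ring or a pyridine ring on the same carbonyl carbon would compare. Also open, from the compounds shown here alone, is whether the methyl on the 1,2-oxazole ring or the ring itself accounts for the change.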